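The source may hold more compounds than are shown below. What is called first, only, known or untested is meant among the compounds shown, and "the series" means these compounds.

Compound 3 is `Cc1cn([C@@H]2O[C@H](CO[Si](C)(C)C(C)(C)C)[C@@]3(OS(=O)(=O)C=C3NCC(=O)OCc3ccccc3)[C@H]2O[Si](C)(C)C(C)(C)C)c(=O)n(C)c1=O`. In a functional assay on HEL cells (Homo sapiens) for cytotoxicity, read by microscopy (on this read-out higher numbers stand for lower toxicity in this test and lower numbers for higher toxicity in this test), compound 3 gives only a limit of the assay, >= 400000 nM; this is the situation described by the limit of >= 400000 nM in this assay, at which 1 of the 3 values shown sits. The comparators are compound 1, `COC(=O)CC(=O)NC1=CS(=O)(=O)O[C@@]12[C@@H](CO[Si](C)(C)C(C)(C)C)O[C@@H](n1cc(C)c(=O)n(C)c1=O)[C@@H]2O[Si](C)(C)C(C)(C)C`, and compound 2, `C=C(C)C(=O)NC(=O)NC1=CS(=O)(=O)O[C@@]12[C@@H](CO[Si](C)(C)C(C)(C)C)O[C@@H](n1cc(C)c(=O)n(C)c1=O)[C@@H]2O[Si](C)(C)C(C)(C)C`. In this assay compound 1 gives 400000 nM and compound 2 gives 20000 nM. Between them, a 20-fold lower number from compound 1 to compound 2 (1.30 log units; beyond the scatter). Going on, an at least 20-fold higher number from compound 2 to compound 3 (1.30 log units; beyond the scatter), while a number no lower from compound 1 to compound 3 (the limit leaves the size open). Compound 2 is thus the only one of the three that stands clearly apart.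

Compound 4 is `Cc1cn([C@@H]2O[C@H](CO[Si](C)(C)C(C)(C)C)[C@@]3(OS(=O)(=O)C=C3NC(=O)NC(=O)c3ccccc3)[C@H]2O[Si](C)(C)C(C)(C)C)c(=O)n(C)c1=O`. The change is benzoylcarbamoyl in place of (benzyloxycarbonyl)methyl on an amine nitrogen. The step from compound 1 to compound 2 bears on it most directly: compound 2 carries a ((1-methylethenyl)carbonyl)carbamoyl group on the amine nitrogen, and compound 4 a benzoylcarbamoyl group at the same place. The step from compound 2 to compound 3 is the removal of such a group and went the other way, by a large amount. Among the measured compounds shown here, the step of an at least 10-fold lower number from compound 3 to compound 4 (1.00 log units; beyond the scatter) is therefore expected to be a large fall in the number, back toward the region of compound 2, though the phenyl ring entering with compound 4 has no measured counterpart here. Compound 4 is estimated at 40000 nM, with a range from 10000 nM to 400000 nM.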

Compound 4, minimum cytotoxic concentration: >= 80000 nM
Compound 4: a limit, no number; the forecaster's own chance of this, stated with the estimate: 20%; at least 2.0-fold (0.30 log units) between middle value and limit.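

In this assay compound 4 gives >= 80000 nM, which is a limit of the assay and not a number. With the rest of the structure held, phenyl in place of 1-methylethenyl on a carbonyl carbon gives an at least 4.0-fold higher number from compound 2 to compound 4 (0.60 log units; beyond the scatter), so in this pair the carbamoyl link on the amine nitrogen does not by itself carry the low number of compound 2, and the group on the far carbonyl carbon also counts. The steps joining compound 4 to compound 3 and to compound 1 cannot be read, as the limits leave their size open: the limit of >= 80000 nM in this assay, at which 1 of the 4 values shown sits.

Still open, from the compounds shown here alone, is whether the low number of compound 2 goes with the double bond of the 1-methylethenyl group, which an isopropyl or an ethyl group on the same carbonyl carbon would test against the phenyl of compound 4. Also open, going by these compounds, is how the number in this assay moves with a longer chain on that carbonyl carbon, or with a plain amine or a carboxylic acid in place of benzoylcarbamoyl on the amine nitrogen.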